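Hydroxyphenyl for fluorophenyl and tolerance in liver cells

This account rests on a few compounds, and the source may have more. Where it says the series, first, only, none or still open, it means among the compounds named here.

compound 1 `CC(C)Cc1nn(-c2nccs2)cc1C(=O)NCc1ccccc1F`: > 100000 nM
compound 2 `CCOC(=O)c1cn(-c2nccs2)nc1CC(C)C`: > 100000 nM
compound 3 `CCOC(=O)c1cn(-c2ccccc2[N+](=O)[O-])nc1CC(C)C`: 4850 nM

All three were tested in a toxicity assay on HepG2 2.2.15 cells (Homo sapiens) for cytotoxicity, read by CCK-8 assay, with a stated time of 8 days; a higher number here means that more compound is tolerated, a lower number that less compound is tolerated. For compound 1 the reading is a limit of the assay, not a number. The reading for compound 2 is likewise a limit. Compound 3 gives a measured number in this assay. Compound 1 thus stands at the limit of > 100000 nM in this assay, at which 2 of the 3 values shown sit, and one further value shown is also a limit. Compound 4 `CC(C)Cc1nn(-c2nccs2)cc1C(=O)NCc1ccc(O)cc1` differs from compound 1 by 4-hydroxyphenyl in place of 2-fluorophenyl on a saturated chain carbon bound to an amide-type nitrogen. Within the data shown here, no step between measured compounds is on hand to anchor this change, so the expectation is no step beyond the scatter, and the step from compound 1 to compound 4 is expected to be a number no higher from compound 1 to compound 4 (the limit leaves the size open). Compound 4 is therefore estimated at 100000 nM, within 30000 nM to 300000 nM, most likely again reported only as a limit.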

Compound 4, half-maximal cytotoxic concentration: > 100000 nM
Compound 4: only a limit was reported; the forecaster's own chance of this, stated with the estimate: 80%; the middle value lies on the limit itself.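

Compound 4, like compound 1, is reported only as a limit of the assay, so no step between the two can be read: the limit of > 100000 nM in this assay, at which 3 of the 4 values shown sit.

The compounds shown leave open whether 4-hydroxyphenyl in place of 2-fluorophenyl changes how much compound the cells tolerate.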